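Shortening the Diethylamino Chain on a Shared Core

The compounds below may be only part of what the source reports. "The series", "measured", "known", "first", "only" and "open" are said of these compounds alone.

Compound 1 `CN(C)CCCNc1nc(-c2ccc(NC(=O)Nc3ccc(F)cc3)cc2)nc2c(Cl)c(Cl)sc12` gives 650 nM in a functional assay on NCI-H460 cells (Homo sapiens) for cytotoxicity, read by MTT assay, with a stated time of 72 h; on this read-out lower numbers stand for stronger inhibition and higher numbers for weaker inhibition.
Compound 2 `CN(C)CCNc1nc(-c2ccc(NC(=O)Nc3ccc(F)cc3)cc2)nc2c(Cl)c(Cl)sc12` gives 590 nM in this assay.
Compound 3 `CCN(CC)CCCNc1nc(-c2ccc(NC(=O)Nc3ccc(F)cc3)cc2)nc2c(Cl)c(Cl)sc12` gives 450 nM in this assay.

Compound 3 holds the lowest number of the three, yet both steps to it stay within the scatter: a 1.4-fold lower number from compound 1 to compound 3 (0.16 log units; within the scatter) and a 1.3-fold lower number from compound 2 to compound 3 (0.12 log units; within the scatter). Compound 4 `CCN(CC)CCNc1nc(-c2ccc(NC(=O)Nc3ccc(F)cc3)cc2)nc2c(Cl)c(Cl)sc12` differs from compound 3 by diethylamino in place of (diethylamino)methyl on a saturated chain carbon, two bonds along the chain from a nitrogen on an aromatic ring. For the measured compounds named here, the one measured step that matches this change is a 1.1-fold lower number from compound 1 to compound 2 (0.04 log units; within the scatter), the same change made on the dimethylamino chain, and it stayed within the scatter. Nothing in these numbers points to a real shift, so the step of a 1.0-fold lower number from compound 3 to compound 4 (0.02 log units; within the scatter) is expected to remain within the scatter. Compound 4 is therefore estimated at 430 nM, with a range from 200 nM to 900 nM.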

Compound 4, half-maximal inhibitory concentration: 500 nM
Compound 4: middle estimate off by 1.2-fold (0.07 log units), on the low side; measured number inside the range.
By their numbers in this assay, from the lowest: compounds 3, 4, 2 and 1 (each within the scatter of the next).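

Shortening the chain from 3-(diethylamino)propyl to 2-(diethylamino)ethyl gives a 1.1-fold higher number from compound 3 to compound 4 (0.05 log units; within the scatter), so the chain length on the diethylamino series behaves as it does on the dimethylamino series. On the shorter chain, diethylamino in place of dimethylamino gives a 1.2-fold lower number from compound 2 to compound 4 (0.07 log units; within the scatter), and diethylamino in place of (dimethylamino)methyl gives a 1.3-fold lower number from compound 1 to compound 4 (0.11 log units; within the scatter). The swap from dimethylamino to diethylamino now reads alike at both chain lengths: the same change on two cores in this assay, a 1.4-fold lower number (0.16 log units; within the scatter) from compound 1 to compound 3 and a 1.2-fold lower number (0.07 log units; within the scatter) from compound 2 to compound 4, 1.2-fold (0.09 log units) apart, within the scatter of two such steps.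

Still open, going by these compounds, is whether a ring amine such as morpholine, or a longer chain such as 4-(diethylamino)butyl, would stay within the scatter or move the number beyond it.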